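Removing a Methyl from the Acryloyl Chain of Compound 2

The compounds below may be only part of what the source reports. "The series", "measured", "known", "first", "only" and "open" are said of these compounds alone.

Compound 1 `COC(=O)c1cc(CNc2cc(OC)c(OC)c(OC)c2)ccc1OC`: 49600 nM
Compound 2 `C=C(C)C(=O)N(Cc1ccc(OC)c(O)c1)c1cc(OC)c(OC)c(OC)c1`: 390 nM
Compound 3 `C/C=C/C(=O)N(Cc1ccc(OC)c(Br)c1)c1cc(OC)c(OC)c(OC)c1`: 6430 nM

Of the compounds shown here, three have been measured in a functional assay on MGC-803 cells (Homo sapiens) for inhibition, read by MTT assay, with a stated time of 48 h; on this read-out lower numbers stand for stronger inhibition and higher numbers for weaker inhibition. Compound 2 stands lowest of the three numbers; the nearest is compound 3, whose value lies beyond the scatter above it, and the furthest is compound 1, whose value lies still further above it, also beyond the scatter. Compound 4 `C=CC(=O)N(Cc1ccc(OC)c(O)c1)c1cc(OC)c(OC)c(OC)c1` has not yet been measured. It differs from compound 2 in one place: hydrogen in place of methyl on a double-bonded chain carbon bound to a carbonyl carbon. The methyl leaves and a hydrogen enters, the rest of the molecule being kept.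

For the measured compounds named here, no measured pair shows this particular change, so there is no step to lean on. The change is small in what it counts, and the expectation is that the step from compound 2 to compound 4 in this assay stays within the usual scatter, in either direction, as the estimate a 1.2-fold higher number from compound 2 to compound 4 (0.06 log units; within the scatter) expresses. On that basis compound 4 is expected to give about 450 nM, in a range from 150 nM to 1500 nM.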

Compound 4, half-maximal inhibitory concentration: 62 nM
For compound 4 the middle estimate is 7.3-fold (0.86 log units) above the measured one; measured number below the stated range.
By their numbers in this assay, from the lowest: compound 4; then compound 2; then compound 3; then compound 1.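

Going from 1-methylethenyl to vinyl in this assay gives a 6.3-fold lower number from compound 2 to compound 4 (0.80 log units; beyond the scatter), a step beyond the scatter. For the compounds shown here, the earlier compounds held no pair differing at this place, and this step is the first sign that the double-bonded chain carbon bound to a carbonyl carbon is not indifferent to what it carries: with the rest of the molecule kept, hydrogen there gives the lower number and methyl the higher. Nothing at hand explains the size of this step.

Only methyl and hydrogen are shown on that carbon, so it remains open how a fluorine or an ethyl there would compare with either. As far as these compounds go, it is also open whether the exchange would give a step of similar size with an amine in place of the hydroxyl of compound 2 and compound 4.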